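The source may report more compounds than this note shows. Statements on the series, on what has been measured and on what is new or still open speak of the compounds shown alone.

Measured so far:
Compound 1 `Cc1ccccc1S(=O)(=O)N1CCN(c2cnc(C(=O)NCc3ccc(F)cc3)cn2)CC1` gives 0.95 in an ADME assay on microsomes from liver (Homo sapiens), read by LC-MS, using NADPH, tested at 10 uM; a higher number here means that the liver removes a larger share of the compound in one pass, a lower number that the liver removes a smaller share.
Compound 2 `Cc1ccccc1S(=O)(=O)N1CCN(c2ccc(C(=O)NCc3cncs3)nn2)CC1` gives 0.59 in this assay.

Compound 2 holds the lowest of the two numbers shown; compound 1 stands above it by a gap that is beyond the usual scatter. Among the measured compounds shown here, compound 1 and compound 2 differ in more than one place, so no single step connects them, and the two values show only that compound 1 is removed to a larger share than compound 2.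

Compound 3 `Cc1ccccc1S(=O)(=O)N1CCN(c2ccc(C(=O)NCc3ccc(F)cc3)nn2)CC1` is not yet measured. It differs from compound 2 in one place: 4-fluorophenyl in place of 1,3-thiazol-5-yl on a saturated chain carbon bound to an amide-type nitrogen. The 4-fluorobenzyl group that enters is the same one carried by compound 1, whose 0.95 sits well above compound 2. On that basis compound 3 is expected to rise in this assay by a step of a number 0.21 higher from compound 2 to compound 3 (beyond the scatter), beyond the scatter. The estimate for compound 3 is 0.8, within 0.62 to 0.95.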

Compound 3, hepatic extraction ratio: 0.56
Estimate against measurement, compound 3: 0.24 above; the measured number lies below the stated range.
By their numbers in this assay, from the lowest: compounds 3 and 2 (each within the scatter of the next); then compound 1.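

In this assay the exchange of 1,3-thiazol-5-yl for 4-fluorophenyl on a saturated chain carbon bound to an amide-type nitrogen gives a number 0.030 lower from compound 2 to compound 3 (within the scatter), so the two rings are not told apart at this position. Compound 3 carries the same 4-fluorobenzyl group as compound 1, yet compound 3 gives 0.56 while compound 1 gives 0.95, so this group alone does not go with the high number. No measurement at hand bears on the reason for this result.

Going by these compounds, whether a longer chain, an amine or a carboxylic acid in place of these rings would shift the number remains open. Also open, on these data alone, is whether 1,3-thiazol-5-yl on the core of compound 1 would give a number like that of its 4-fluorophenyl counterpart.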